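The compounds below may be only part of what the source reports. "The series", "measured", "known", "first", "only" and "open" are said of these compounds alone.

In a functional assay on thoracic aorta for antagonist activity at Alpha-1D adrenergic receptor (Rattus norvegicus) (a higher number here means a more potent compound, by a factor of ten per unit of this negative logarithm, a lower number a less potent compound), compound 1 `COc1cccc(OC)c1OCCNCCOc1ccccc1OCc1ccccc1C` gives 8.64, compound 2 `COc1cccc(OC)c1OCCNCCOc1ccccc1OCc1cccc([N+](=O)[O-])c1` gives 9.28, and compound 3 `COc1cccc(OC)c1OCCNCCOc1ccccc1OCc1ccc([N+](=O)[O-])cc1` gives 9.41.

Compound 3 holds the highest number of the three, but its gap to compound 2 is within the scatter (a number 0.13 log units higher from compound 2 to compound 3 (within the scatter)), so the two cannot be ranked; the step from compound 1 is beyond it (a number 0.77 log units higher from compound 1 to compound 3 (beyond the scatter)). Compound 4 `COc1cccc(OC)c1OCCNCCOc1ccccc1OCc1ccc(OC(C)C)cc1` differs from compound 3 by isopropoxy in place of nitro on an aromatic carbon. Among the compounds with values here, the steps that bear on this change are a number 0.64 log units higher from compound 1 to compound 2 (beyond the scatter) and a number 0.77 log units higher from compound 1 to compound 3 (beyond the scatter), both modest shifts from exchanging the group on the same benzyl arm. Within the data shown here, no measured pair exchanges nitro for isopropoxy, so the direction is uncertain; a modest drop toward the level of compound 1 is expected. The expected step is a number 0.51 log units lower from compound 3 to compound 4 (beyond the scatter). Compound 4 is therefore estimated at 8.9, with a range from 8.3 to 9.5.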

Compound 4, negative logarithm of the antagonist equilibrium constant: 9.14
The estimate for compound 4 lay 0.24 log units below the measured number; low and high end bracket the measured number.
By their numbers in this assay, from the lowest: compound 1; then compounds 4, 2 and 3 (each within the scatter of the next).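

In this assay, isopropoxy on this aromatic carbon serves as well as nitro (a number 0.27 log units lower from compound 3 to compound 4 (within the scatter)), and compound 4 also cannot be told apart from the 3-nitrophenyl compound (a number 0.14 log units lower from compound 2 to compound 4 (within the scatter)), so a nitro group is not required for this level. The 4-isopropoxyphenyl group keeps its edge over 2-methylphenyl (a number 0.50 log units higher from compound 1 to compound 4 (beyond the scatter)). No measurement here accounts for these results.

As far as these compounds go, whether an amine, a carboxylic acid or a longer alkoxy chain on the same carbon would hold this level remains open.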